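The source may hold more compounds than are shown below. What is called first, only, known or untested is meant among the compounds shown, and "the series" means these compounds.

Compound 1 `Cn1cncc1C(OCc1ccc(C#N)cc1C#CC(C)(C)C)c1ccc(C#N)cc1` gives 76.9 nM in a functional assay on NIH3T3 cells (Mus musculus); on this read-out higher numbers stand for an effect only at larger amounts of compound and lower numbers for an effect already at smaller amounts.
Compound 2 `Cn1cncc1C(OCc1ccc(C#N)cc1C#CC1(O)CCCCC1)c1ccc(C#N)cc1` gives 1.93 nM.
Compound 3 `Cn1cncc1C(OCc1ccc(C#N)cc1C#CCCc1ccccc1)c1ccc(C#N)cc1` gives 130 nM.

Compound 1 stands second highest of these three numbers. Its nearest neighbour is compound 3, reached by a 1.7-fold higher number from compound 1 to compound 3 (0.23 log units; within the scatter); its furthest is compound 2, reached by a 40-fold lower number from compound 1 to compound 2 (1.60 log units; beyond the scatter). Compound 4 `Cn1cncc1C(OCc1ccc(C#N)cc1-c1ccc(C#N)cc1)c1ccc(C#N)cc1` differs from compound 1 by 4-cyanophenyl in place of 3,3-dimethylbut-1-yn-1-yl on an aromatic carbon. For the measured compounds named here, no measured step removes the triple bond itself: both steps from compound 1 only exchange the group on the triple-bonded carbon, one within the scatter and one large. The measured steps therefore give no clear direction for this assay, and a step of modest size, in either direction, is expected. For compound 4 the estimate in this assay is 60 nM, with a range from 10 nM to 350 nM, expected to mean a 1.3-fold lower number from compound 1 to compound 4 (0.11 log units; within the scatter).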

Compound 4, half-maximal effective concentration: < 0.1 nM
Compound 4: only a limit was reported (the forecaster's own chance of this, stated with the estimate: 5%); middle value at least 600-fold (2.77 log units) from the limit.
By their numbers in this assay, from the lowest: compound 2; then compounds 1 and 3 (each within the scatter of the next). At a limit, below all of these: compound 4.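

In this assay compound 4 carries a limit and not a number: the limit of < 0.1 nM in this assay, at which 1 of the 4 values shown sits. At this aromatic carbon, a directly attached 4-cyanophenyl in place of the alkynyl groups gives an at least 760-fold lower number from compound 1 to compound 4 (2.88 log units; beyond the scatter) and an at least 1300-fold lower number from compound 3 to compound 4 (3.11 log units; beyond the scatter). For the compounds shown here, it also outdoes the best earlier group, 2-(1-hydroxycyclohexyl)ethynyl, with an at least 19-fold lower number from compound 2 to compound 4 (1.28 log units; beyond the scatter), so this position does not depend on the alkynyl link that all the earlier compounds carried. The compounds shown leave open whether the cyano group of the 4-cyanophenyl counts, as against an unsubstituted phenyl or a 4-methoxyphenyl. They also leave open whether a saturated cyclohexyl ring on this carbon would serve equally.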